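Adding Trifluoromethyl to the Aromatic Ring of Compound 1

A few compounds are considered here, and "the series" means these few. Any claim that something is new, unique, unknown or untested is made for them only; others in the source may bear on it.

In a functional assay on ECa-109 cells for inhibition, with ECa-109 cell line (Homo sapiens) as the target, read by sulforhodamine B assay (a lower number here means a stronger inhibitor, a higher number a weaker inhibitor), compound 1 (`O=C1C(Nc2ccccc2)=CC(=O)c2c1nc1n2[C@H]2OC[C@@H](O)[C@H]2OC1`) gives 3560 nM and compound 2 (`O=C1C=C(Nc2ccccc2F)C(=O)c2c1nc1n2[C@H]2OC[C@@H](O)[C@H]2OC1`) gives 2760 nM, two numbers within the scatter of each other. Compound 3 (`O=C1C=C(NC2CCCCC2)C(=O)c2c1nc1n2[C@H]2OC[C@@H](O)[C@H]2OC1`) reaches only a limit of the assay, > 16000 nM. Compound 4 (`O=C1C(Nc2ccc(C(F)(F)F)cc2)=CC(=O)c2c1nc1n2[C@H]2OC[C@@H](O)[C@H]2OC1`) carries trifluoromethyl in place of hydrogen on an aromatic carbon of compound 1, para to a large group: trifluoromethyl in place of hydrogen on an aromatic carbon. Going by the values given here, the one measured step, an at least 5.7-fold higher number from compound 2 to compound 3 (0.76 log units; beyond the scatter), replaces the aromatic ring with cyclohexyl, whereas compound 4 keeps its aromatic ring, so that step is only a loose guide. No step beyond the scatter is therefore expected, and the expected change is a 1.3-fold lower number from compound 1 to compound 4 (0.10 log units; within the scatter). Compound 4 is estimated at 2800 nM, within a range of 1000 nM to 8000 nM.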

Compound 4, half-maximal inhibitory concentration: 2250 nM
The estimate for compound 4 lay 1.2-fold (0.09 log units) above the measured number, and the stated range covers the measured number.
By their numbers in this assay, from the lowest: compounds 4, 2 and 1 (each within the scatter of the next). At a limit, above all of these: compound 3.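

Trifluoromethyl in place of hydrogen on this aromatic carbon, para to a large group, gives a 1.6-fold lower number from compound 1 to compound 4 (0.20 log units; within the scatter) in this assay. Going by these compounds alone, this is the first single change at this place on the ring, and it shows that a group of 4 heavy atoms can enter here without a step that stands out from repeat measurements. Nothing measured here offers a reason for this result.

As far as these compounds go, whether a carboxylic acid, an amine or a longer chain at this place would shift the number beyond the scatter remains open. So does the effect of trifluoromethyl elsewhere on the ring.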